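Chloromethylbenzyl purines: dropping the second ring chloro

The compounds below may be only part of what the source reports. "The series", "measured", "known", "first", "only" and "open" are said of these compounds alone.

Measured so far:
compound 1 `ClCc1ccc(Cn2cnc3c(Cl)ncnc32)cc1`: 5490 nM
compound 2 `ClCc1ccccc1Cn1cnc2c(Cl)nc(Cl)nc21`: 3020 nM

In a functional assay on NCI/ADR-RES cells (Homo sapiens) for cytotoxicity, read by sulforhodamine B assay, with a stated time of 48 h (a lower number here means a stronger inhibitor of growth, a higher number a weaker inhibitor of growth), compound 1 gives 5490 nM and compound 2 gives 3020 nM; the two values lie within the scatter of each other, so neither stands apart. Compound 3 `ClCc1ccccc1Cn1cnc2c(Cl)ncnc21` is not yet measured. It differs from compound 2 by hydrogen in place of chloro on an aromatic carbon. For the measured compounds named here, no measured pair isolates this change; compound 1 also carries a single chloro on the core but differs elsewhere as well, so it gives no clean read. A small loss, probably within the scatter, is expected, as the step of a 1.5-fold higher number from compound 2 to compound 3 (0.17 log units; within the scatter). Compound 3 is expected to give 4500 nM, between 1500 nM and 13000 nM.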

Compound 3, concentration for total growth inhibition: 4670 nM
Beside the measured number, compound 3's estimate is 1.0-fold (0.02 log units) below it; measured number inside the range.
By their numbers in this assay, from the lowest: compounds 2, 3 and 1 (each within the scatter of the next).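

In this assay this pair gives the first clean read of this position, and the step is a 1.5-fold higher number from compound 2 to compound 3 (0.19 log units; within the scatter) for hydrogen in place of chloro on the aromatic carbon between two ring nitrogen atoms. Chloro on this carbon is thus not required for a value in this range, and its loss cannot be told apart from the scatter.

Open, on these data alone, is whether an amine or a methoxy group on this carbon would carry the number beyond the scatter. Also open, as far as these compounds go, is what a hydroxymethyl group in place of chloromethyl would give. No supporting data bear on this result.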